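A few compounds are considered here, and "the series" means these few. Any claim that something is new, unique, unknown or untested is made for them only; others in the source may bear on it.

In an assay for binding affinity to Corticotropin releasing factor receptor (Rattus norvegicus) (a lower number here means a stronger inhibitor, a higher number a weaker inhibitor), compound 2 `CCCC(C)n1c(CC)nc2c(-c3ccc(/C(C)=N\OC)cc3Cl)ccnc21` gives 2.3 nM. Going by the values given here, that is the higher of the two numbers so far, yet its nearest neighbour, compound 1 `CCC(CCOC)n1c(OC)nc2c(-c3ccc(OC(F)(F)F)cc3Cl)ccnc21`, gives 1.9 nM in this assay, a gap within the scatter, so neither ranks above the other. Compound 3 `CCCC(C)n1c(CC)nc2c(-c3ccc(C(C)=O)cc3Cl)ccnc21` differs from compound 2 by a group of 3 heavy atoms (2 carbon, 1 oxygen; no ring) in place of a group of 5 heavy atoms (3 carbon, 1 nitrogen, 1 oxygen; no ring), on an aromatic carbon. Among the compounds with values here, no measured pair shows this change, so no step can be drawn from it. The expected step is a 1.7-fold higher number from compound 2 to compound 3 (0.24 log units; within the scatter), small and possibly not beyond the scatter. For compound 3 the estimate is 4 nM, with a range from 1.5 nM to 12 nM.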

Compound 3, inhibition constant: 1 nM
The estimate for compound 3 lay 4.0-fold (0.60 log units) above the measured number; measured number below the stated range.
By their numbers in this assay, from the lowest: compounds 3, 1 and 2 (each within the scatter of the next, the first and the last beyond it).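

Acetyl in place of the group of 5 heavy atoms on this aromatic carbon, meta to a chloro group, gives a 2.3-fold lower number from compound 2 to compound 3 (0.36 log units; beyond the scatter) in this assay, so the larger group is not needed here for a low number. The change also takes the hydrogen-bond acceptors from 2 to 1 without a loss in this assay. Nothing measured here accounts for the step. On these data alone, whether an amine or a carboxylic acid on this carbon would keep the number low remains open, as does whether acetyl would give a similar step on the core of compound 1 .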